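This account rests on a few compounds, and the source may have more. Where it says the series, first, only, none or still open, it means among the compounds named here.

compound 1 `OC(c1ccc(Cl)cc1)(c1cccnc1)c1ccccc1Cl` gives 61300 nM
compound 2 `OC(c1ccc(Cl)cc1)(c1cccnc1)c1ccccc1F` gives > 100000 nM (a limit)
compound 3 `OC(c1ccc(Cl)cc1)(c1cnccn1)c1ccccc1Cl` gives > 100000 nM (a limit)

Compound 1 is the only one of the three with a true number in an ADME assay on L6 cells (Rattus norvegicus) for cytotoxicity, read by resazurin assay, with a stated time of 72 h (a lower number here means a stronger inhibitor, a higher number a weaker inhibitor), and the other two entries are limits. The series is framed by the limit of > 100000 nM in this assay, at which 2 of the 3 values shown sit, and a further limit cannot be ruled out for the next compound.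

That compound is compound 4 `COC(c1ccc(Cl)cc1)(c1cccnc1)c1ccccc1Cl`, which carries methyl in place of hydrogen on an oxygen on a saturated carbon, so hydroxy becomes methoxy.

Two measured steps start from the same compound: an at least 1.6-fold higher number from compound 1 to compound 2 (0.21 log units; that floor lies within the scatter) and an at least 1.6-fold higher number from compound 1 to compound 3 (0.21 log units; that floor lies within the scatter). Each changes a different place in the molecule, and each gives only a floor within the scatter. Neither touches the hydroxy, so neither gives a size for this change.

In this assay compound 1 gives 61300 nM. Among the measured compounds shown here, with no measured step at that oxygen, no step beyond the scatter is expected in either direction from compound 1. The estimated step is a 1.1-fold lower number from compound 1 to compound 4 (0.05 log units; within the scatter), which stays within the scatter.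

For compound 4 the expected value is 55000 nM, with an estimated range from 20000 nM to 100000 nM.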

Compound 4, half-maximal inhibitory concentration: 58700 nM
For compound 4 the middle estimate is 1.1-fold (0.03 log units) below the measured one; the range from low to high includes it.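

In this assay, the oxygen on a saturated carbon now has a measured step of its own: a 1.0-fold lower number from compound 1 to compound 4 (0.02 log units; within the scatter). The earlier steps shown here at the aromatic halogen and at the pyridin-3-yl ring end in limits and give only floors, whereas this step joins two true numbers and so has a readable size. On the core of compound 1, replacing hydroxy with methoxy therefore leaves the reading within the scatter, and in this pair the hydrogen on that oxygen is not needed for a measurable value in this assay.

As far as these compounds go, a single pair cannot show whether this holds on the cores of compound 2 or compound 3, and the top of the assay's range stays close to the numbers in hand: the limit of > 100000 nM in this assay, at which 2 of the 4 values shown sit. Also open is whether a longer chain on that oxygen, or an amine or a carboxylic acid in place of the hydroxy, would leave the reading within the scatter or move it beyond, in either direction.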